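Swapping One Group on a Shared Core

This account rests on a few compounds, and the source may have more. Where it says the series, first, only, none or still open, it means among the compounds named here.

Three measured compounds share one core and differ only in a single group on an aromatic carbon. In a functional assay (mitochondria, liver) with Rattus norvegicus as the target (a lower number here means a stronger inhibitor, a higher number a weaker inhibitor), compound 1 (`O=S(=O)(CS(=O)(=O)C(F)(F)F)c1ccc(OC(F)(F)F)cc1`) gives 2950000 nM. Compound 2 (`CC(C)(C)c1ccc(S(=O)(=O)CS(=O)(=O)C(F)(F)F)cc1`) gives 2800000 nM, and compound 3 (`O=S(=O)(CS(=O)(=O)C(F)(F)F)c1ccc(Cl)cc1`) gives 4000000 nM. Compound 3 therefore cannot be told apart from the other two, as the data show a 1.4-fold higher number from compound 1 to compound 3 (0.13 log units; within the scatter) and a 1.4-fold higher number from compound 2 to compound 3 (0.15 log units; within the scatter).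

Compound 4 (`O=S(=O)(CS(=O)(=O)C(F)(F)F)c1ccc(C(F)(F)F)cc1`) has trifluoromethyl in place of chloro on an aromatic carbon, para to a large group: trifluoromethyl in place of chloro on an aromatic carbon. This exact swap has not been measured, so the nearest guides are the other swaps at the same place. Replacing trifluoromethoxy with tert-butyl gave a 1.1-fold lower number from compound 1 to compound 2 (0.02 log units; within the scatter), and exchanging tert-butyl for chloro gave a 1.4-fold higher number from compound 2 to compound 3 (0.15 log units; within the scatter). Three different groups at this place have thus left this assay within its usual scatter, although three compounds are a small base. No step beyond the scatter is expected for the new swap, and the estimated step is a 1.3-fold lower number from compound 3 to compound 4 (0.10 log units; within the scatter). For compound 4 the expected value is 3200000 nM, with an estimated range from 1800000 nM to 5500000 nM.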

Compound 4, half-maximal inhibitory concentration: 5400000 nM
Beside the measured number, compound 4's estimate is 1.7-fold (0.23 log units) below it; measured number inside the range.
By their numbers in this assay, from the lowest: compounds 2, 1, 3 and 4 (each within the scatter of the next).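

Trifluoromethyl in place of chloro gives a 1.4-fold higher number from compound 3 to compound 4 (0.13 log units; within the scatter) in this assay, so a fourth group on this aromatic carbon, para to a large group, still leaves the number within the scatter of compound 3. The comparisons with the other two groups read the same way, with a 1.9-fold higher number from compound 2 to compound 4 (0.29 log units; within the scatter) and a 1.8-fold higher number from compound 1 to compound 4 (0.26 log units; within the scatter), so this assay cannot separate any of the four compounds, even with a group of 4 heavy atoms entering where chloro has 1. This position has now taken four different groups without a step that can be read as real, but nothing shown here explains why the numbers stay so close together.

On these data alone, it remains open whether a group of another kind at this position, such as an amine, a carboxylic acid or a longer chain, would produce a step beyond the scatter. As far as these compounds go, it is also open whether changes to the shared core elsewhere, away from this aromatic carbon, would move the number in this assay more than these four groups do.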